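Compound 1 to compound 4: swapping the basic side chain

The compounds below may be only part of what the source reports. "The series", "measured", "known", "first", "only" and "open" are said of these compounds alone.

The compounds share one core carrying a side chain on an aromatic nitrogen. Compound 1 `CN1CCN(CCCCCCn2c3c(c4ccccc42)C(=O)c2c[n+]([O-])c4ccccc4c2C3=O)CC1` gives 2400 nM in a functional assay on MDA-MB-231 cells (Homo sapiens) for cytotoxicity, read by MTT assay, with a stated time of 72 h (a lower number here means a stronger inhibitor, a higher number a weaker inhibitor), the highest of the two numbers recorded there. Compound 2 `CC1(C)O[C@@H](CO)[C@H](Cn2cc(Cn3c4c(c5ccccc53)C(=O)c3c[n+]([O-])c5ccccc5c3C4=O)nn2)O1` gives 680 nM, a lower number than that of compound 1. Compound 3 `CC1(C)OC[C@@H](Cn2cc(Cn3c4c(c5ccccc53)C(=O)c3c[n+]([O-])c5ccccc5c3C4=O)nn2)O1` is reported only as a limit of the assay, > 1000 nM; the same limit is described as the limit of > 1000 nM in this assay, at which 1 of the 3 values shown sits. For the measured compounds named here, the single measured step, an at least 1.4-fold higher number from compound 2 to compound 3 (0.16 log units; that floor lies within the scatter), concerns the 2,2-dimethyl-1,3-dioxolan-4-yl part of the side chain and its floor sits within the scatter, so it does not speak to the change at hand: 4-hydroxypiperidin-1-yl in place of 3-(4-methylpiperazin-1-yl)propyl on a saturated chain carbon, three bonds along the chain from an aromatic nitrogen. Going by the values given here, compound 4 `O=C1c2c[n+]([O-])c3ccccc3c2C(=O)c2c1c1ccccc1n2CCCN1CCC(O)CC1` therefore carries a change for which no measured pair exists, and the only guide is where compound 1 stands. The expected step is a 1.2-fold lower number from compound 1 to compound 4 (0.08 log units; within the scatter), none beyond the scatter. Compound 4 is estimated at 2000 nM, within a range from 700 nM to 6000 nM.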

Compound 4, half-maximal inhibitory concentration: 280 nM
For compound 4 the middle estimate is 7.1-fold (0.85 log units) above the measured one, outside the stated range (below it).
By their numbers in this assay, from the lowest: compound 4; then compound 2; then compound 1.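

In this assay, an 8.6-fold lower number from compound 1 to compound 4 (0.93 log units; beyond the scatter) shows that this position can respond well beyond the scatter when 4-hydroxypiperidin-1-yl replaces 3-(4-methylpiperazin-1-yl)propyl. For the compounds shown here, the one earlier step, within the 2,2-dimethyl-1,3-dioxolan-4-yl side chains, had a floor within the scatter, so it showed no such clear response. This single change alters the ring, the chain length and the hydrogen-bond donor count together, and nothing measured here gives a cause for the step.

The compounds shown leave open which of these differences carries the step, and a plain piperidin-1-yl on the chain of compound 4 would separate the hydroxyl from the ring. Going by these compounds alone, whether 4-hydroxypiperidin-1-yl keeps this number on a longer chain, such as the one in compound 1, also remains open.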